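Cytotoxicity of a methylated hydroquinone analogue

A few compounds are considered here, and "the series" means these few. Any claim that something is new, unique, unknown or untested is made for them only; others in the source may bear on it.

compound 1 `CC(C)=CCCC1=CCc2c(O)ccc(O)c2C1`: 4900 nM
compound 2 `CC(=O)Oc1ccc(OC(C)=O)c2c1CC=C(CCC=C(C)C)C2`: 3600 nM

In a functional assay on A549 cells (Homo sapiens) for cytotoxicity (a lower number here means a stronger inhibitor, a higher number a weaker inhibitor), compound 1 gives 4900 nM, which lies within the scatter of compound 2 at 3600 nM. Within the data shown here, these two values therefore set no order between the compounds. Compound 3 `CC(C)=CCCC1=CCc2c(O)cc(C)c(O)c2C1` differs from compound 1 by methyl in place of hydrogen on an aromatic carbon. Among the measured compounds shown here, no measured pair shows this change, so the data offer no direct guide to its size. The estimated step, a 1.1-fold lower number from compound 1 to compound 3 (0.04 log units; within the scatter), is expected to stay within the scatter, with no clear direction. In this assay compound 3 is expected at 4500 nM, within an estimated range of 1700 nM to 12000 nM.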

Compound 3, half-maximal inhibitory concentration: 3800 nM
The estimate for compound 3 lay 1.2-fold (0.07 log units) above the measured number; the measured number falls inside the stated range.
By their numbers in this assay, from the lowest: compounds 2, 3 and 1 (each within the scatter of the next).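

Methyl in place of hydrogen on an aromatic carbon, ortho to a hydroxy group, gives a 1.3-fold lower number from compound 1 to compound 3 (0.11 log units; within the scatter) in this assay. Among these compounds, this is the first measured reading of this change, and it shows that one added methyl at this place leaves the number within the scatter, with no direction that can be read. Nothing measured here explains this result.

As far as these compounds go, whether a larger group at this place, such as methoxy, an amine or a carboxylic acid, would move the number beyond the scatter stays open. The compounds shown also leave open what a longer chain would do there.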